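Lipophilicity notes: from compound 2 to compound 4

A few compounds are considered here, and "the series" means these few. Any claim that something is new, unique, unknown or untested is made for them only; others in the source may bear on it.

The series is compared in a physicochemical assay for lipophilicity, read by HPLC, at pH 7.5; on this read-out higher numbers stand for higher lipophilicity and lower numbers for lower lipophilicity. Compound 1 `CCOc1ccccc1-c1ccc(-c2nc3cncc(Cl)c3c(N[C@H](CC)C(N)=O)c2C#N)cc1` sits at the top of the measured numbers, giving 3.7 in this assay. Compound 3 `CCOc1ccccc1-c1ccc(-c2nc3cnccc3c(C[C@H](C)C(=O)O)c2C#N)cc1` is at the bottom, giving 2.2 in this assay. Compound 2 `CC[C@@H](Nc1c(C#N)c(-c2ccc(-c3cccc(Cl)c3OC)cc2)nc2cnccc12)C(N)=O` is the second highest of the three numbers, giving 3.1 in this assay; its nearest neighbour is compound 1, which stands higher by an amount beyond the scatter, and its furthest is compound 3, which stands lower, again beyond the scatter. Among the compounds with values here, none of these three pairs differs in only one place, so no single-point step is available from the measured compounds.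

Compound 4 `CC[C@@H](Nc1c(C#N)c(-c2ccc(-c3ccc(Cl)cc3)cc2)nc2cnccc12)C(N)=O` is not yet measured in this assay. It differs from compound 2 in one place: 4-chlorophenyl in place of 3-chloro-2-methoxyphenyl on an aromatic carbon. The change removes the methoxy and moves the chlorine, leaving the ring para to a large group otherwise unchanged. Within the data shown here, with no comparable step among the measured compounds to lean on, the expected step from compound 2 to compound 4 is small, a number 0.20 log units higher from compound 2 to compound 4 (within the scatter), most likely within the scatter or just above it in the upward direction. Compound 4 is therefore expected to give about 3.3 in this assay, with a range from 2.9 to 3.7.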

Compound 4, distribution coefficient: 3.1
For compound 4 the middle estimate is 0.20 log units above the measured one, and the stated range covers the measured number.
By their numbers in this assay, from the lowest: compound 3; then compounds 2 and 4 (each within the scatter of the next); then compound 1.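

In this assay this position now has its first single-place step, and 4-chlorophenyl in place of 3-chloro-2-methoxyphenyl reads no change at the digits printed from compound 2 to compound 4 (within the scatter) on an aromatic carbon para to a large group. The number at this position therefore stays inside the scatter through an exchange that takes away the methoxy, with its hydrogen-bond acceptor, and relocates the chlorine on the ring. Both edits travel in this one step, so it gives only their combined outcome and cannot be split into a share for each, and nothing available bears on why the outcome is what it is.

The compounds shown leave open what the methoxy alone or the relocated chlorine alone would do at this position, since no pair here separates the two edits and opposing contributions cannot be told apart from no contribution. Also open, as far as these compounds go, is whether this ring position stays as flat for groups of a different kind, such as an aminomethyl group or a carboxylic acid in place of the chlorine.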